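Chlorinated aryl on a triazole nitrogen: an expectation

The source may report more compounds than this note shows. Statements on the series, on what has been measured and on what is new or still open speak of the compounds shown alone.

Compound 1, `CCOc1ccccc1-n1nncc1CN1C(=O)C2(C(C#N)=C(N)Oc3c2c2nc4ccccc4nc2c2ccccc32)c2ccccc21`: > 50000 nM
Compound 2, `Cc1cccc(-n2nncc2CN2C(=O)C3(C(C#N)=C(N)Oc4c(N)cc5nc6ccccc6nc5c43)c3ccccc32)c1`: > 50000 nM

Of the compounds shown here, two sharing a spiro core have been tested in a functional assay on HCT-116 cells (Homo sapiens) for antiproliferative activity, read by MTT assay, with a stated time of 48 h; a higher number here means a weaker inhibitor, a lower number a stronger inhibitor. Compound 1 reaches only the limit of the assay, at > 50000 nM. Compound 2 likewise gives a limit and not a number, > 50000 nM. Compound 2 therefore sits at the edge of what the assay can report, together with compound 1, as summarised by the limit of > 50000 nM in this assay, at which 2 of the 2 values shown sit.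

Compound 3, `Cc1ccc(Cl)cc1-n1nncc1CN1C(=O)C2(C(C#N)=C(N)Oc3c(N)cc4nc5ccccc5nc4c32)c2ccccc21`, is not yet measured. It differs from compound 2 by 5-chloro-2-methylphenyl in place of 3-methylphenyl on an aromatic nitrogen.

For the measured compounds named here, no step between measured compounds is available, and both values shown are limits. The change is small in size, and the expectation is that the step that the limit leaves unreadable from compound 2 to compound 3 stays within the scatter of repeated measurements, with compound 3 most likely remaining a limit as well. Compound 3 is estimated at 60000 nM, in the range 20000 nM to 200000 nM.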

Compound 3, half-maximal inhibitory concentration: 37200 nM
For compound 3 the middle estimate is 1.6-fold (0.21 log units) above the measured one, and the stated range covers the measured number.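

For the compounds shown here, compound 3 is the only one of the three compounds to give a number rather than a limit in this assay, which shows that this position on the triazole nitrogen can carry an aryl group with a readable value on the shared core. The change to 5-chloro-2-methylphenyl gives an at least 1.3-fold lower number from compound 2 to compound 3 (0.12 log units; that floor lies within the scatter), so the floor of the step alone does not separate the two compounds. The step may be larger, but its true size cannot be read because compound 2 carries only a limit: the limit of > 50000 nM in this assay, at which 2 of the 3 values shown sit.

The one step changes the chlorine and the place of the methyl together, and the compounds shown leave open which of the two counts. They also leave open how a fluoro group, a methoxy group or an amine on this aryl ring would read.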